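Cytotoxicity on a shared aryloxy core: tribromophenyl step

The compounds below may be only part of what the source reports. "The series", "measured", "known", "first", "only" and "open" are said of these compounds alone.

Measured so far in an ADME assay on MT4 cells (Homo sapiens) for cytotoxicity, read by MTT assay, with a stated time of 4 days; on this read-out higher numbers stand for lower toxicity in this test and lower numbers for higher toxicity in this test:
compound 1 `COc1ccc(Oc2nc(Nc3ccc(C#N)cc3)nc3ccccc23)cc1`, 340000 nM
compound 2 `N#Cc1ccc(Nc2nc(Oc3ccc(Cl)cc3)c3ccccc3n2)cc1`, 198000 nM
compound 3 `CCCOc1cc(C#N)cc(OC)c1Oc1nc(Nc2ccc(C#N)cc2)nc2ccccc12`, 5200 nM

Compound 1 gives the highest number of the three in this assay. Its nearest neighbour is compound 2: the step of a 1.7-fold lower number from compound 1 to compound 2 (0.23 log units; within the scatter) sits within the scatter, so the two cannot be ordered. Going by the values given here, compound 3 stands far lower, at 5200 nM against 340000 nM for compound 1, and that gap lies beyond the scatter; no single-point step joins these two compounds.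

The next compound is compound 4 `N#Cc1ccc(Nc2nc(Oc3c(Br)cc(Br)cc3Br)c3ccccc3n2)cc1`. It differs from compound 1 by 2,4,6-tribromophenyl in place of 4-methoxyphenyl on an oxygen on an aromatic ring.

Among the compounds with values here, only one measured step touches the same position, the swap of the substituent on the aryl ether in a 1.7-fold lower number from compound 1 to compound 2 (0.23 log units; within the scatter), and it stayed within the scatter. Within the data shown here, no measured step exchanges one substituent for three, and compound 3, the only other heavily substituted aryl ether, gives a much lower number. On this basis the expected step of a 5.7-fold lower number from compound 1 to compound 4 (0.75 log units; beyond the scatter) is downward and is estimated to pass the scatter, though with wide uncertainty. Compound 4 is therefore expected to give about 60000 nM in this assay, within 12000 nM to 250000 nM.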

Compound 4, half-maximal cytotoxic concentration: 58000 nM
Beside the measured number, compound 4's estimate is 1.0-fold (0.01 log units) above it; low and high end bracket the measured number.
By their numbers in this assay, from the lowest: compound 3; then compound 4; then compounds 2 and 1 (each within the scatter of the next).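

In this assay this place on the oxygen now gives steps beyond the scatter: the step of a 5.9-fold lower number from compound 1 to compound 4 (0.77 log units; beyond the scatter) and the step of a 3.4-fold lower number from compound 2 to compound 4 (0.53 log units; beyond the scatter) both point the same way, whereas the earlier step of a 1.7-fold lower number from compound 1 to compound 2 (0.23 log units; within the scatter) stayed within the scatter and could not order its two compounds. The group on this oxygen can therefore shift the read-out, and 2,4,6-tribromophenyl gives the lower number, meaning higher toxicity in this test, against both 4-methoxyphenyl and 4-chlorophenyl, although both steps are modest. No measured evidence accounts for this shift.

The compounds shown leave open whether all three bromine atoms are needed for the shift or whether a phenyl group with a single bromine would give a similar number. They also leave open how the read-out would respond to a phenyl group carrying an amine or a carboxylic acid at this place on the shared core.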